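One Added Methoxy on the Lowest of Three Values

The source may hold more compounds than are shown below. What is called first, only, known or untested is meant among the compounds shown, and "the series" means these compounds.

Measured in a functional assay on HCT-116 cells (Homo sapiens) for cytotoxicity, read by crystal violet staining, with a stated time of 7 days (on this read-out higher numbers stand for weaker inhibition and lower numbers for stronger inhibition), as follows:
compound 1 `COc1ccc2c(c1)C=C(/C=C/C(=O)C1=Cc3cc(OC)ccc3OC1)CO2` gives 12900 nM
compound 2 `COc1ccc(/C=C/C(=O)C2=Cc3cc(OC)ccc3OC2)cc1` gives 590 nM
compound 3 `COc1cc(OC)cc(C(=O)/C=C/C2=Cc3cc(Br)ccc3OC2)c1` gives 3400 nM

Compound 2 holds the lowest number of the three, and so the strongest inhibition here. Its gaps to compound 3, the nearest, and to compound 1, the furthest, both lie beyond the scatter.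

Compound 4 `COc1ccc2c(c1)C=C(C(=O)/C=C/c1ccc(OC)cc1OC)CO2` has not yet been measured. It differs from compound 2 by one change, (methoxy in place of hydrogen on an aromatic carbon), methoxy in place of hydrogen on an aromatic carbon, ortho to a large group and meta to a methoxy group.

Among the compounds with values here, no two measured compounds differ in one place, so no measured step speaks to this change. The expectation rests on the values alone: compound 2 at 590 nM sits at the low end, and compound 3 at 3400 nM and compound 1 at 12900 nM both lie higher. A new compound is therefore more likely to land above compound 2 than below it.

The expected 2.4-fold higher number from compound 2 to compound 4 (0.38 log units; beyond the scatter) is a modest move toward a higher number, only a little beyond the scatter. In this assay the estimate for compound 4 is 1400 nM, with an expected range from 300 nM to 6000 nM for this measurement.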

Compound 4, half-maximal inhibitory concentration: 3970 nM
Compound 4: middle estimate off by 2.8-fold (0.45 log units), on the low side, and the stated range covers the measured number.
By their numbers in this assay, from the lowest: compound 2; then compounds 3 and 4 (each within the scatter of the next); then compound 1.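

In this assay, within the data shown here, this is the first comparison in the set between two compounds that differ in one place: methoxy in place of hydrogen on an aromatic carbon, ortho to a large group and meta to a methoxy group, comes with a 6.7-fold higher number from compound 2 to compound 4 (0.83 log units; beyond the scatter). This shows that the position is not indifferent to the change, since this one methoxy goes with a modest move toward weaker inhibition that lies beyond the scatter. The earlier compounds shown here could only place compound 2 at the low end of the values, whereas this pair ties a rise in the number to a single site on the aromatic ring.

Nothing available here explains why the number rises with this change at this position. On these data alone, it also remains open whether a fluorine, a hydroxyl or an amine at the same position would shift the number in the same direction, and whether this methoxy would have a similar effect elsewhere on the ring.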